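Replacing Nitro with Bromo on the Shared Core

The compounds below may be only part of what the source reports. "The series", "measured", "known", "first", "only" and "open" are said of these compounds alone.

Of the compounds shown here, three built on one core have been tested in an ADME assay on NIH3T3 cells (Mus musculus) for cytotoxicity, read by MTT assay; a lower number here means a stronger inhibitor, a higher number a weaker inhibitor. Compound 1 `N#Cc1c(-c2ccccc2Cl)c(C#N)c(=O)n(/N=C/c2cn(-c3ccccc3)nc2-c2ccccc2)c1N` gives 84 ug/mL in this assay, and compound 2 `N#Cc1c(-c2ccc(Cl)cc2)c(C#N)c(=O)n(/N=C/c2cn(-c3ccccc3)nc2-c2ccccc2)c1N` gives 64 ug/mL, with a 1.3-fold lower number from compound 1 to compound 2 (0.12 log units; within the scatter). Compound 3 `N#Cc1c(-c2ccccc2[N+](=O)[O-])c(C#N)c(=O)n(/N=C/c2cn(-c3ccccc3)nc2-c2ccccc2)c1N` reaches only the limit of the assay, > 200 ug/mL, so its result is a limit rather than a number (the limit of > 200 ug/mL in this assay, at which 1 of the 3 values shown sits). Compound 3 therefore stands at the weakest-inhibiting end of the three, as an at least 2.3-fold higher number from compound 1 to compound 3 (0.37 log units; beyond the scatter) and an at least 3.1-fold higher number from compound 2 to compound 3 (0.49 log units; beyond the scatter) both show.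

Compound 4 `N#Cc1c(-c2ccccc2Br)c(C#N)c(=O)n(/N=C/c2cn(-c3ccccc3)nc2-c2ccccc2)c1N` has not been measured. It differs from compound 3 by bromo in place of nitro on an aromatic carbon. The measured steps that bear on this change are the two that introduced the nitro group, an at least 2.3-fold higher number from compound 1 to compound 3 (0.37 log units; beyond the scatter) and an at least 3.1-fold higher number from compound 2 to compound 3 (0.49 log units; beyond the scatter), and compound 1 carries chloro at the same place. Taking the nitro away again for a halogen is expected to undo that step and bring the number back down in this assay. The estimate for compound 4 is 90 ug/mL, within 45 ug/mL to 200 ug/mL, which amounts to an expected at least 2.2-fold lower number from compound 3 to compound 4 (0.34 log units; beyond the scatter).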

Compound 4, half-maximal inhibitory concentration: 174 ug/mL
The estimate for compound 4 lay 1.9-fold (0.29 log units) below the measured number; low and high end bracket the measured number.
By their numbers in this assay, from the lowest: compounds 2 and 1 (each within the scatter of the next); then compound 4. At a limit, above all of these: compound 3.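

In this assay, the place ortho to a large group proves sensitive to the choice of halogen, so a halogen there does not by itself return the number to the level of the chloro compounds: bromo in place of chloro gives a 2.1-fold higher number from compound 1 to compound 4 (0.32 log units; beyond the scatter), and the change from 4-chlorophenyl to 2-bromophenyl gives a 2.7-fold higher number from compound 2 to compound 4 (0.43 log units; beyond the scatter). Bromo in place of nitro gives an at least 1.1-fold lower number from compound 3 to compound 4 (0.06 log units; that floor lies within the scatter), so the compounds do not establish that this change lowers the number by more than the scatter. The result for compound 3 is a limit and not a number: the limit of > 200 ug/mL in this assay, at which 1 of the 4 values shown sits.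

As far as these compounds go, how far the number would move with fluoro, methoxy or an amine at this place remains open. So does how far compound 3 truly lies from compound 4.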